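A Second Sulfo Group on a Disaccharide Binder

The source may hold more compounds than are shown below. What is called first, only, known or untested is meant among the compounds shown, and "the series" means these compounds.

For the measured compounds named here, compound 3 `CC(=O)N[C@H]1[C@@H](OC[C@@H](O)[C@@H](O)[C@H](O)[C@@H](O)CNc2cccc(NC(=O)CCCCC3CCSS3)c2)O[C@H](CO)[C@H](O)[C@@H]1O[C@@H]1O[C@H](C(=O)O)[C@@H](O)[C@H](OS(=O)(=O)O)[C@H]1O` is the only member of this small set with a reported number: in an assay on isolated protein for binding affinity to fibroblast growth factor 2 (Homo sapiens), read by surface plasmon resonance (a higher number here means weaker binding, a lower number tighter binding), compound 3 gives 25 nM. Its two relatives share the same core. Compound 1 `CC(=O)N[C@H]1[C@@H](OC[C@@H](O)[C@@H](O)[C@H](O)[C@@H](O)CNc2cccc(NC(=O)CCCCC3CCSS3)c2)O[C@H](CO)[C@H](O)[C@@H]1O[C@@H]1O[C@H](C(=O)O)[C@@H](O)[C@H](O)[C@H]1O`, which carries no sulfo group, is reported in this assay as "not active" (no number reported). Compound 2 `CC(=O)N[C@H]1[C@@H](OC[C@@H](O)[C@@H](O)[C@H](O)[C@@H](O)CNc2cccc(NC(=O)CCCCC3CCSS3)c2)O[C@H](CO)[C@H](OS(=O)(=O)O)[C@@H]1O[C@@H]1O[C@H](C(=O)O)[C@@H](O)[C@H](O)[C@H]1O`, which carries a single sulfo group, is reported in this assay as "not active" (no number reported). Among the measured compounds, then, only compound 3 yields a measurable dissociation constant.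

Compound 4 `CC(=O)N[C@H]1[C@@H](OC[C@@H](O)[C@@H](O)[C@H](O)[C@@H](O)CNc2cccc(NC(=O)CCCCC3CCSS3)c2)O[C@H](CO)[C@H](OS(=O)(=O)O)[C@@H]1O[C@@H]1O[C@H](C(=O)O)[C@@H](O)[C@H](OS(=O)(=O)O)[C@H]1O` keeps everything in compound 3 and adds one more group: sulfo in place of hydrogen on an oxygen on a saturated carbon. Going by the values given here, no measured pair differs in exactly this way, so the size of the step is open. Compound 2 shows that this kind of group alone gave "not active" (no number reported), which says nothing about what it does on top of compound 3. The step from compound 3 to compound 4 is expected to be modest, a 1.7-fold lower number from compound 3 to compound 4 (0.22 log units; within the scatter), within or just beyond the scatter. For compound 4 the estimate is 15 nM, with a range from 4 nM to 60 nM.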

Compound 4, dissociation constant: 41 nM
Estimate against measurement, compound 4: 2.7-fold (0.44 log units) below; the measured number falls inside the stated range.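

With a second sulfo group present, this change can finally be read as a number: in this assay it gives a 1.6-fold higher number from compound 3 to compound 4 (0.21 log units; within the scatter) and so no real shift in binding. Compound 2 carries this same group and has no reported number, yet compound 4 keeps a measurable dissociation constant, so the group on this oxygen does not prevent measurable binding when compound 3's sulfo group is also present. Nothing shown here offers an explanation for this result.

The compounds shown leave open whether a phosphate group or an amine on this saturated carbon, in place of the sulfooxy group, would keep binding at a similar level. They also leave open what a sulfo group on the other hydroxy groups of the shared core would do.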